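The source may hold more compounds than are shown below. What is called first, only, known or untested is meant among the compounds shown, and "the series" means these compounds.

Compound 1 `CCCn1ccc2cc(/C(C)=C/C(=O)Nc3ccccc3OCCCC(=O)O)ccc21` carries propyl on the aromatic nitrogen of the shared core, while compound 2 `CCCC(C(C)C)n1ccc2cc(/C(C)=C/C(=O)Nc3ccccc3OCCCC(=O)O)ccc21` carries 1-isopropylbutyl at that position. For the measured compounds named here, in an assay on Prostate gland for inhibition of steroid 5-alpha-reductase (Rattus norvegicus) (on this read-out higher numbers stand for weaker inhibition and lower numbers for stronger inhibition), compound 1 gives 190 nM, the highest of the two numbers so far, and compound 2 gives 7.2 nM. Going by the values given here, the only measured step is a 26-fold lower number from compound 1 to compound 2 (1.42 log units; beyond the scatter). Compound 3 `COc1ccc(Cn2ccc3cc(/C(C)=C/C(=O)Nc4ccccc4OCCCC(=O)O)ccc32)cc1` is the next member; relative to compound 1 it shows (4-methoxyphenyl in place of ethyl on a saturated chain carbon bound to an aromatic nitrogen). The step from compound 1 to compound 2 bears on this only loosely: both changes enlarge the group on the aromatic nitrogen, but a ring entering is a change of a different kind from the branched chain of compound 2. Given the size of a 26-fold lower number from compound 1 to compound 2 (1.42 log units; beyond the scatter), a lower number is expected for compound 3, though a smaller step than that one, estimated as a 4.8-fold lower number from compound 1 to compound 3 (0.68 log units; beyond the scatter). Compound 3 is therefore estimated at 40 nM in this assay, with a range from 10 nM to 160 nM.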

Compound 3, half-maximal inhibitory concentration: 480 nM
Compound 3: middle estimate off by 12-fold (1.08 log units), on the low side; measured number above the stated range.
By their numbers in this assay, from the lowest: compound 2; then compound 1; then compound 3.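

In this assay, replacing propyl with 4-methoxybenzyl on the aromatic nitrogen gives a 2.5-fold higher number from compound 1 to compound 3 (0.40 log units; beyond the scatter) and so runs opposite to a 26-fold lower number from compound 1 to compound 2 (1.42 log units; beyond the scatter) at the same position. A larger group here therefore does not by itself give a lower number, and compound 1, with the smallest group of the three, lies between the other two. The branched chain and the ring-bearing group are far apart, with a 67-fold higher number from compound 2 to compound 3 (1.82 log units; beyond the scatter) as the widest step in the set, so the identity of the entering group matters at this position, not just its size.

Plain benzyl and cyclohexylmethyl on the aromatic nitrogen would help show whether the higher number of compound 3 goes with the methoxy group, the aromatic ring or the absence of branching. No measurement at hand accounts for either step.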